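A few compounds are considered here, and "the series" means these few. Any claim that something is new, unique, unknown or untested is made for them only; others in the source may bear on it.

Measured so far:
Compound 1, `O=C(/C=C/c1ccc2c(c1)B(O)OC2)c1ccc(Cl)cc1`, gives 3700 nM.
Compound 2, `O=C(/C=C/c1ccc2c(c1)B(O)OC2)c1cccc(F)c1`, gives 4800 nM.

Both numbers come from a functional assay on SK-OV-3 cells (Homo sapiens) for cytotoxicity, read by MTT assay, with a stated time of 48 h; on this read-out higher numbers stand for weaker inhibition and lower numbers for stronger inhibition. Within the data shown here, the only other value shown, that of compound 1, lies within the scatter of the value of compound 2, so the two cannot be told apart on these numbers. Compound 3, `O=C(/C=C/c1ccc2c(c1)B(O)OC2)c1cccc(O)c1`, is not yet measured. It differs from compound 2 by hydroxy in place of fluoro on an aromatic carbon. Among the measured compounds shown here, the only measured step, a 1.3-fold higher number from compound 1 to compound 2 (0.11 log units; within the scatter), also swapped one substituent on this ring for another and stayed within the scatter; it does not, however, involve a hydroxy group, so no measured step tests the fluoro-to-hydroxy exchange directly. Given that the one change on this ring left the number essentially unmoved, the expectation is a step of a 1.1-fold higher number from compound 2 to compound 3 (0.06 log units; within the scatter), that is, no shift beyond the scatter. Compound 3 is therefore estimated at 5500 nM, with a range from 2200 nM to 14000 nM.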

Compound 3, half-maximal inhibitory concentration: 3800 nM
Compound 3: middle estimate off by 1.4-fold (0.16 log units), on the high side; low and high end bracket the measured number.
By their numbers in this assay, from the lowest: compounds 1, 3 and 2 (each within the scatter of the next).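

In this assay, hydroxy, which brings one hydrogen-bond donor and one hydrogen-bond acceptor where fluoro brings neither, gives a 1.3-fold lower number from compound 2 to compound 3 (0.10 log units; within the scatter), so this exchange at this position does not separate the two compounds. Going from 4-chlorophenyl to 3-hydroxyphenyl gives a 1.0-fold higher number from compound 1 to compound 3 (0.01 log units; within the scatter), which means that the three groups on this carbonyl carbon, chloro, fluoro and hydroxy included, cannot be told apart on these numbers. No measured evidence is available to explain this flat result.

On these data alone, whether an amine, a carboxylic acid or a longer chain on this ring would move the number beyond the scatter stays open. As far as these compounds go, all three compounds also share one core, so the effect of any change to that core remains unknown.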